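Swapping 4-ethylpiperazin-1-yl for morpholin-4-yl on a thiocarbonyl carbon

A few compounds are considered here, and "the series" means these few. Any claim that something is new, unique, unknown or untested is made for them only; others in the source may bear on it.

Measured so far:
- Compound 1 `COc1ccc(-c2coc3cc(OCCCCSC(=S)N4CCN(C(=O)OC(C)(C)C)CC4)ccc3c2=O)cc1`: 4610 nM
- Compound 2 `CCN1CCN(C(=S)SCCCOc2ccc3c(=O)c(-c4ccc(OC)cc4)coc3c2)CC1`: 7080 nM

In a functional assay on PC-3 cells (Homo sapiens) for inhibition, read by MTT assay, with a stated time of 48 h (a lower number here means a stronger inhibitor, a higher number a weaker inhibitor), compound 2 gives 7080 nM, which lies within the usual scatter of repeated measurements from compound 1 at 4610 nM. The two numbers therefore cannot be ranked.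

The next compound, compound 3 `COc1ccc(-c2coc3cc(OCCCSC(=S)N4CCOCC4)ccc3c2=O)cc1`, has not yet been measured. It has morpholin-4-yl in place of 4-ethylpiperazin-1-yl on a thiocarbonyl carbon. The rest of compound 2 stays the same.

Among the compounds with values here, no measured pair isolates this change, so the data offer only a weak guide. The two measured values sit close together, so no change beyond the scatter is expected in this assay, in either direction. The expected size is a 1.1-fold higher number from compound 2 to compound 3 (0.05 log units; within the scatter). For compound 3 the estimated value is 8000 nM, with an expected range from 3000 nM to 22000 nM.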

Compound 3, half-maximal inhibitory concentration: 27400 nM
Estimate against measurement, compound 3: 3.4-fold (0.53 log units) below; measured number above the stated range.
By their numbers in this assay, from the lowest: compounds 1 and 2 (each within the scatter of the next); then compound 3.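

In this assay, within the data shown here, compound 2 and compound 3 form the first pair that differs in only one place, and that swap of morpholin-4-yl for 4-ethylpiperazin-1-yl gives a 3.9-fold higher number from compound 2 to compound 3 (0.59 log units; beyond the scatter) on the thiocarbonyl carbon. The group at this position therefore matters to the result, with compound 3 the weaker inhibitor of the pair. This holds even though both groups are six-membered non-aromatic rings with 2 hetero atoms and have the same counts of hydrogen-bond donors and acceptors. No measurement at hand explains the step.

As far as these compounds go, it remains open whether the step follows the ring oxygen or the loss of the ethyl group, and a piperidin-1-yl or an unsubstituted piperazin-1-yl group on the same carbon would help separate the two. From the compounds shown here alone, whether the swap has the same effect with a different chain also remains open.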